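Glutamine benzyl ester analogue of a purine glycinamide

A few compounds are considered here, and "the series" means these few. Any claim that something is new, unique, unknown or untested is made for them only; others in the source may bear on it.

Measured so far:
compound 1 `O=C(CN(c1nc(Cl)nc2[nH]cnc12)C1CC1)NCC(=O)OCc1ccccc1` gives 18%
compound 2 `O=C(O)CNC(=O)CN(c1nc(Cl)nc2[nH]cnc12)C1CC1` gives 9.08%
compound 3 `NC(=O)C[C@H](NC(=O)CN(c1ncnc2c1ncn2C1CCCCO1)C1CC1)C(=O)OCc1ccccc1` gives 21.7%

In a functional assay on the whole organism (Tail, strain ICR) with Mus musculus as the target, in the tail flick test, with a stated time of 150 min, at a dose of 25 umol/kg by the oral route (a lower number here means a weaker effect, a higher number a stronger effect of the compound at the dose given), compound 1 stands second of three numbers. Its nearest neighbour is compound 3, whose value lies within the scatter of that of compound 1, and its furthest is compound 2, also within the scatter. Among the compounds with values here, the one step between compounds that differ in a single place, a number 8.9 percentage points lower from compound 1 to compound 2 (within the scatter), shows that the hydrogen in place of benzyl on an oxygen next to a carbonyl group left the read-out within the scatter.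

Compound 4 `NC(=O)CC[C@H](NC(=O)CN(c1nc(Cl)nc2[nH]cnc12)C1CC1)C(=O)OCc1ccccc1` differs from compound 1 by 2-carbamoylethyl in place of hydrogen on a saturated chain carbon bound to an amide-type nitrogen and a carbonyl carbon. Within the data shown here, no measured step touches that place; compound 3 carries a related side chain but on a different core, so its value with that of compound 1 shows only that the two lie within the scatter. Among the measured compounds shown here, with the sole measured step, a number 8.9 percentage points lower from compound 1 to compound 2 (within the scatter), itself within the scatter, compound 4 is expected to give 20%, between 8% and 32%, a step of a number 2 percentage points higher from compound 1 to compound 4 (within the scatter) that is not expected to exceed the scatter.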

Compound 4, a percentage reported as activity, at one dose (the size of the read-out at that dose, not a potency): 31.1%
The estimate for compound 4 lay 11.1 percentage points below the measured number; measured number inside the range.
By their numbers in this assay, from the lowest: compounds 2, 1, 3 and 4 (each within the scatter of the next, the first and the last beyond it).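

Putting 2-carbamoylethyl in place of hydrogen on a saturated chain carbon bound to an amide-type nitrogen and a carbonyl carbon gave, in this assay, a number 13.1 percentage points higher from compound 1 to compound 4 (beyond the scatter) and so moved the read-out beyond the scatter, which the earlier step of a number 8.9 percentage points lower from compound 1 to compound 2 (within the scatter) at the benzyl ester did not do. This carbon is therefore a place where a change on the core of compound 1 registers in the read-out at this single dose and time, although one substituent gives no trend. Nothing available here explains the rise.

On these data alone, it remains open whether the gain depends on the terminal primary amide or on the chain alone, and whether a carboxylic acid, an amine or a longer chain at this carbon would match it. Also open, as far as these compounds go, is whether the benzyl ester still matters once 2-carbamoylethyl is present.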